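From 3-fluoro-4-methoxyphenyl to 3,5-difluorophenyl: compound 3 to compound 4

The compounds below may be only part of what the source reports. "The series", "measured", "known", "first", "only" and "open" are said of these compounds alone.

- Compound 1 `C=C[C@@](C)(/C=C/c1ccc(Nc2ccccc2)cc1)CCC=C(C)C` gives > 36600 nM as a limit
- Compound 2 `C=C[C@@](C)(/C=C/c1ccc(Nc2ccc(OC)cc2)cc1)CCC=C(C)C` gives > 36600 nM as a limit
- Compound 3 `C=C[C@@](C)(/C=C/c1ccc(Nc2ccc(OC)c(F)c2)cc1)CCC=C(C)C` gives > 36600 nM as a limit

In an ADME assay on HEK293 cells (Homo sapiens) for cytotoxicity, with a stated time of 72 h (a lower number here means that less compound is needed, a higher number that more compound is needed for the effect), compound 3 has no number, only the limit > 36600 nM as its result. All the measured compounds stand at the limit of > 36600 nM in this assay, at which 3 of the 3 values shown sit, and no number separates them.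

Compound 4 `C=C[C@@](C)(/C=C/c1ccc(Nc2cc(F)cc(F)c2)cc1)CCC=C(C)C` differs from compound 3 on a nitrogen on an aromatic ring, with 3,5-difluorophenyl in place of 3-fluoro-4-methoxyphenyl on a nitrogen on an aromatic ring and nothing else changed.

Three measured changes to this same group bear on it, namely a step that the two limits leave unreadable from compound 1 to compound 2 and a step that the two limits leave unreadable from compound 1 to compound 3 and a step that the two limits leave unreadable from compound 2 to compound 3 and none of them has a readable size or direction. No step beyond the scatter is therefore expected in this assay and compound 4 will most likely be reported as a limit again. The expected change is (a step that the limit leaves unreadable from compound 3 to compound 4). For compound 4 the estimate is 40000 nM with an expected range from 20000 nM to 80000 nM if a number is reported at all.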

Compound 4, half-maximal effective concentration: > 36600 nM
Compound 4: only a limit was reported; the forecaster's own chance of this, stated with the estimate: 85%; the middle value is on the limit's open side.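

In this assay compound 4 gives > 36600 nM as a limit and not a number. Among these compounds, no step among compound 1, compound 2, compound 3 and compound 4 can be read, as all four share one limit: the limit of > 36600 nM in this assay, at which 4 of the 4 values shown sit. The compounds shown leave open whether their groups on the nitrogen differ at all in this read-out.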